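Replacing the tetrahydropyranyl pyrazole in compound 2

The compounds below may be only part of what the source reports. "The series", "measured", "known", "first", "only" and "open" are said of these compounds alone.

Measured so far:
compound 1 `Cn1cc(-c2nc3c(-c4ccc(CNC(=O)c5nc(C(C)(C)C)no5)c(F)c4)ccnc3[nH]2)cn1` 2 ug/mL
compound 2 `Cc1c(-c2nc3c(-c4ccc5c(c4)CCC[C@H]5NC(=O)c4nc(C(C)(C)C)no4)ccnc3[nH]2)cnn1C1CCOCC1` 7 ug/mL

In a physicochemical assay for solubility, in simulated intestinal fluid (on this read-out lower numbers stand for lower solubility and higher numbers for higher solubility), compound 2 gives the higher of the two numbers, and compound 1 lies clearly below it. Compound 3 `Cc1nn(C(C)C)c(C)c1-c1nc2c(-c3ccc4c(c3)CCC[C@H]4NC(=O)c3nc(C(C)(C)C)no3)ccnc2[nH]1` differs from compound 2 in one place: a group of 10 heavy atoms (8 carbon, 2 nitrogen; one five-membered aromatic ring with 2 hetero atoms) in place of a group of 12 heavy atoms (9 carbon, 2 nitrogen, 1 oxygen; one five-membered aromatic ring with 2 hetero atoms, one six-membered non-aromatic ring with 1 hetero atom), on an aromatic carbon. The group that leaves carries the oxygen of a six-membered non-aromatic ring; the group that enters has none. On that basis compound 3 is expected to fall somewhat, with a 2.3-fold lower number from compound 2 to compound 3 (0.37 log units; beyond the scatter) as the estimated step, a change that may not rise beyond the usual scatter. For compound 3 the estimate in this assay is 3 ug/mL, with a range from 1 ug/mL to 10 ug/mL.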

Compound 3, solubility: 56 ug/mL
The estimate for compound 3 lay 19-fold (1.27 log units) below the measured number, outside the stated range (above it).
By their numbers in this assay, from the lowest: compound 1; then compound 2; then compound 3.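

In this assay, the exchange on an aromatic carbon between two ring nitrogen atoms gives an 8.0-fold higher number from compound 2 to compound 3 (0.90 log units; beyond the scatter) and is the first single-place change shown at this position. The entering group has no oxygen and no six-membered non-aromatic ring, so in this pair neither feature is needed for the higher number. No measurement bears on the reason for the rise. Because this one step changes the whole group, the contributions of its parts cannot be separated. As far as these compounds go, how an amine or a carboxylic acid would read at this position remains open.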